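A Halogen Swap Among Readings Held at a Limit

The source may report more compounds than this note shows. Statements on the series, on what has been measured and on what is new or still open speak of the compounds shown alone.

In an ADME assay on microsomes from liver (Canis lupus familiaris) for metabolic stability (a higher number here means that the compound lasts longer, a lower number that the compound disappears faster), compound 3 `Nc1nc(NCCNc2ncc(-c3ncc[nH]3)c(-c3cc(F)c(Cl)cc3F)n2)ccc1[N+](=O)[O-]` gives > 0.5 h as its reading, which is a limit and not a number. Compound 1 `Nc1nc(NCCNc2ncc(-c3ncc[nH]3)c(-c3ccccc3Br)n2)ccc1[N+](=O)[O-]` gives > 0.5 h as its reading, again only a limit. Compound 2 `Nc1nc(NCCNc2ncc(-c3ncc[nH]3)c(-c3ccc(F)cc3Br)n2)ccc1[N+](=O)[O-]` gives > 0.5 h as its reading, also only a limit. the limit of > 0.5 h in this assay, at which 3 of the 3 values shown sit, sums up where the three stand.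

Compound 4 `Nc1nc(NCCNc2ncc(-c3ncc[nH]3)c(-c3ccc(Br)cc3Cl)n2)ccc1[N+](=O)[O-]` differs from compound 3 by 4-bromo-2-chlorophenyl in place of 4-chloro-2,5-difluorophenyl on an aromatic carbon on an aromatic carbon, with 4-bromo-2-chlorophenyl in place of 4-chloro-2,5-difluorophenyl. The measured steps bearing on this are a step that the two limits leave unreadable from compound 1 to compound 3 and a step that the two limits leave unreadable from compound 2 to compound 3 and a step that the two limits leave unreadable from compound 1 to compound 2 on the same phenyl group. None has a readable size, so this assay gives no ground for expecting a step beyond the scatter in either direction. The estimate means an expected step that the limit leaves unreadable from compound 3 to compound 4 and nothing larger. Compound 4 is expected at 0.7 h with an estimated range from 0.4 h to 1.5 h for its half-life.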

Compound 4, half-life: > 0.5 h
Compound 4 gave a limit, no number (the forecaster's own chance of this, stated with the estimate: 80%); the middle value lies beyond the limit too.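

In this assay, among these compounds, compound 4 gives > 0.5 h as a limit and not a number, and so no step between compound 1, compound 2, compound 3 and compound 4 can be read. The compounds shown leave open how far each half-life lies past the shared limit and whether these phenyl swaps change it at all: the limit of > 0.5 h in this assay, at which 4 of the 4 values shown sit.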